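From piperidin-1-yl to pyrrolidin-1-yl on compound 3

The source may hold more compounds than are shown below. What is called first, only, known or untested is meant among the compounds shown, and "the series" means these compounds.

In a functional assay on aorta (Rattus norvegicus, strain Sprague-Dawley) (a lower number here means that less compound is needed, a higher number that more compound is needed for the effect), compound 1 `Cc1ccccc1COc1nc2c(cc1-c1nc(N)cc(N)n1)c(C)nn2-c1ccccc1` gives 290 nM and compound 2 `Cc1nn(-c2ccccc2)c2nc(OCc3ccccc3F)c(-c3nc(N)cc(N)n3)cc12` gives 2200 nM. Compound 3 `Cc1nn(-c2ccccc2)c2nc(OCc3ccccc3F)c(-c3nc(N)c(N4CCCCC4)c(N)n3)cc12` gives 790 nM, the middle of these three numbers. Compound 4 `Cc1nn(-c2ccccc2)c2nc(OCc3ccccc3F)c(-c3nc(N)c(N4CCCC4)c(N)n3)cc12` carries pyrrolidin-1-yl in place of piperidin-1-yl on an aromatic carbon. The step most relevant here is the modest 2.8-fold lower number from compound 2 to compound 3 (0.44 log units; beyond the scatter), made when piperidin-1-yl replaced hydrogen at this place. The equally modest a 7.6-fold higher number from compound 1 to compound 2 (0.88 log units; beyond the scatter) concerns another place and says little. Exchanging one ring for another is a smaller change than adding a ring, so no step beyond the scatter is expected. The expected step is a 1.1-fold lower number from compound 3 to compound 4 (0.05 log units; within the scatter). Compound 4 is estimated at 700 nM, with an expected range of 280 nM to 1800 nM.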

Compound 4, half-maximal effective concentration: 12700 nM
Compound 4: the middle estimate sits 18-fold (1.26 log units) below what was measured, outside the stated range (above it).
By their numbers in this assay, from the lowest: compound 1; then compound 3; then compound 2; then compound 4.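

In this assay this position responds strongly to ring size: a 16-fold higher number from compound 3 to compound 4 (1.21 log units; beyond the scatter) comes with the change from the six-membered piperidin-1-yl to the five-membered pyrrolidin-1-yl. Piperidin-1-yl had lowered the number relative to hydrogen, but pyrrolidin-1-yl raises it, giving a 5.8-fold higher number from compound 2 to compound 4 (0.76 log units; beyond the scatter) and showing that a ring at this place can move the number either way. Nothing available explains this reversal.

From the compounds shown here alone, with only these two rings at this place, it stays open how a morpholin-4-yl ring or an open-chain dimethylamino group would behave.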